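The source may report more compounds than this note shows. Statements on the series, on what has been measured and on what is new or still open speak of the compounds shown alone.

In a functional assay on MCF7 cells (Homo sapiens) for inhibition, read by sulforhodamine B assay, with a stated time of 48 h (a higher number here means a weaker inhibitor of growth, a lower number a stronger inhibitor of growth), compound 1 `CC(C)(C)NCc1c(C(=O)O)nn(-c2ccccc2)c1-c1ccc(F)cc1` gives > 680000 nM as its reading, which is a limit and not a number. Compound 2 `COc1ccc(-c2c(CNC(C)(C)C)c(C(=O)O)nn2-c2ccccc2)cc1` gives > 659000 nM as its reading, also a limit, so compound 2 stands without an exact value. Compound 3 `CC(C)(C)NCc1c(C(=O)O)nn(-c2ccccc2)c1-c1ccc([N+](=O)[O-])cc1` has not yet been measured. It carries nitro in place of methoxy on an aromatic carbon, para to a large group, which is the change from 4-methoxyphenyl to 4-nitrophenyl. Counted out, the difference is nitro in place of methoxy on an aromatic carbon and the rest of the structure stays the same. Among the compounds with values here, one measured step bears on this, since it also swaps one group for another on an aromatic carbon. That step, a step that the two limits leave unreadable from compound 1 to compound 2, offers no size to carry over, so no change beyond the scatter is expected in this assay for the swap to nitro. The expected step is an at least 1.0-fold lower number from compound 2 to compound 3 (0.02 log units; that floor lies within the scatter) as an estimate. For compound 3 the estimated value is 620000 nM within an expected range of 250000 nM to 720000 nM and another limit is the most likely report.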

Compound 3, concentration for 50% growth inhibition: > 634000 nM
Compound 3 gave a limit, no number (the forecaster's own chance of this, stated with the estimate: 80%); middle value at least 1.0-fold (0.00 log units) away from the limit.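

Within the data shown here, compound 1, compound 2 and compound 3 each give only a limit in this assay, so no step among them can be read. The compounds shown leave open whether fluoro, methoxy or nitro on this aromatic carbon makes any difference to growth inhibition, and what exact value any of them would give.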